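The source may report more compounds than this note shows. Statements on the series, on what has been measured and on what is new or still open speak of the compounds shown alone.

Working notes on the series. Compound 1 is `Cc1cccc(C(=O)c2c(OCC(=O)Nc3ccc(S(N)(=O)=O)cc3C)ccc3ccccc23)c1`, compound 2 is `Cc1ccc(C)c(C(=O)c2c(OCC(=O)Nc3ccc(S(N)(=O)=O)cc3C)ccc3ccccc23)c1` and compound 3 is `Cc1ccc(C(=O)c2c(OCC(=O)Nc3ccc(S(N)(=O)=O)cc3C)ccc3ccccc23)c(C)c1`. In an ADME assay on C8166 cells (Homo sapiens) for cytotoxicity, read by colorimetric assay and MTT assay (a lower number here means that less compound is tolerated, a higher number that more compound is tolerated), compound 1 gives 40400 nM, compound 2 gives 47500 nM and compound 3 gives 25500 nM. Compound 1 lies among the three numbers with both of its neighbours inside the usual scatter: a 1.2-fold higher number from compound 1 to compound 2 (0.07 log units; within the scatter) and a 1.6-fold lower number from compound 1 to compound 3 (0.20 log units; within the scatter). Compound 4 is `Cc1cc(S(N)(=O)=O)ccc1NC(=O)COc1ccc2ccccc2c1C(=O)c1cc(Cl)cc(Br)c1`; against compound 1 it shows (3-bromo-5-chlorophenyl in place of 3-methylphenyl on a carbonyl carbon). The measured changes on the carbonyl carbon, a 1.6-fold lower number from compound 1 to compound 3 (0.20 log units; within the scatter) and a 1.9-fold lower number from compound 2 to compound 3 (0.27 log units; within the scatter), stayed within the scatter, so in this assay no step beyond the scatter is expected in either direction. Compound 4 is expected at 40000 nM, between 20000 nM and 80000 nM. For compound 4 this means an expected 1.0-fold lower number from compound 1 to compound 4 (0.00 log units; within the scatter).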

Compound 4, half-maximal cytotoxic concentration: 36600 nM
Compound 4: the middle estimate sits 1.1-fold (0.04 log units) above what was measured; low and high end bracket the measured number.
By their numbers in this assay, from the lowest: compounds 3, 4, 1 and 2 (each within the scatter of the next).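

For the compounds shown here, on the carbonyl carbon, 3-bromo-5-chlorophenyl puts chlorine and bromine where the earlier compounds carried only methyl groups, yet every new step stays within the scatter in this assay (a 1.1-fold lower number from compound 1 to compound 4 (0.04 log units; within the scatter); a 1.4-fold higher number from compound 3 to compound 4 (0.16 log units; within the scatter); a 1.3-fold lower number from compound 2 to compound 4 (0.11 log units; within the scatter)). Among these four compounds, the halogenated and methylated phenyl groups are therefore not separated by this read-out. Nothing available bears on a cause.

Still open, going by these compounds, is whether a carboxylic acid or an amine on the phenyl group would give a step beyond the scatter. The same question stands for a cyclohexyl group in place of the phenyl group.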